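A few compounds are considered here, and "the series" means these few. Any claim that something is new, unique, unknown or untested is made for them only; others in the source may bear on it.

Measured compounds:
compound 1 `CNC(=O)c1ccc(Sc2cccc(NC(=S)Nc3ccc(F)c(F)c3)c2)nc1` — 58200 nM
compound 2 `CNC(=O)c1ccc(Sc2cccc(NC(=S)Nc3cccc(C(F)(F)F)c3)c2)nc1` — 19200 nM
compound 3 `CNC(=O)c1ccc(Sc2ccc(NC(=S)Nc3ccc(F)c(F)c3)cc2)nc1` — 52600 nM

The three compounds were tested in a functional assay on B16-BL6 cells (Mus musculus) for cytotoxicity, read by MTT assay, with a stated time of 48 h; a lower number here means a stronger inhibitor, a higher number a weaker inhibitor. Compound 1 gave 58200 nM in this assay, while compound 2 gave 19200 nM. The two differ in one place: 3-(trifluoromethyl)phenyl in place of 3,4-difluorophenyl on an amide-type nitrogen. This change made a 3.0-fold lower number from compound 1 to compound 2 (0.48 log units; beyond the scatter). Compound 3 gave 52600 nM in this assay, a value that lies within the scatter of compound 1 and beyond the scatter of compound 2. Compound 3 and compound 1 are built from the same atoms joined differently; the difference between the two cores is not broken down here.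

Compound 4 `CNC(=O)c1ccc(Sc2ccc(NC(=S)Nc3cccc(C(F)(F)F)c3)cc2)nc1` is not yet measured. It differs from compound 3 in one place: 3-(trifluoromethyl)phenyl in place of 3,4-difluorophenyl on an amide-type nitrogen. This is the same change that leads from compound 1 to compound 2, at the same kind of place, and it occurs twice among these compounds. Because that earlier change made a 3.0-fold lower number from compound 1 to compound 2 (0.48 log units; beyond the scatter), a step of similar size, a 2.9-fold lower number from compound 3 to compound 4 (0.47 log units; beyond the scatter), is expected from compound 3 to compound 4. This rests on one pair alone, so the expectation is uncertain. Compound 4 is therefore estimated at 18000 nM in this assay, with a likely range from 9000 nM to 36000 nM.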

Compound 4, half-maximal inhibitory concentration: 53100 nM
For compound 4 the middle estimate is 3.0-fold (0.47 log units) below the measured one, outside the stated range (above it).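

In this assay, going by these compounds alone, 3-(trifluoromethyl)phenyl in place of 3,4-difluorophenyl on the amide-type nitrogen gave a 1.0-fold higher number from compound 3 to compound 4 (0.00 log units; within the scatter), so on the core of compound 3 this change produced no step that stands out from the scatter. Set beside the earlier step, the same change did not carry over from one core to the other: the same change on two cores in this assay, a 3.0-fold lower number (0.48 log units; beyond the scatter) from compound 1 to compound 2 and a 1.0-fold higher number (0.00 log units; within the scatter) from compound 3 to compound 4, 3.1-fold (0.49 log units) apart, beyond the scatter of two such steps. Within the data shown here, this shows that the lower number seen for compound 2 cannot be assumed for the same change on the core of compound 3, but with only two pairs it does not show what in the two cores sets the steps apart, or how the change would behave on any further core.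

The compounds shown leave open how the two cores would respond to a phenyl ring bearing an amine or a carboxylic acid on the same nitrogen. They also leave open whether a carbonyl in place of the thiocarbonyl, or a longer chain in place of the methyl on the amide, would keep the two cores apart.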